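A few compounds are considered here, and "the series" means these few. Any claim that something is new, unique, unknown or untested is made for them only; others in the source may bear on it.

Compound 1 `O=C(NCc1ccccc1)N(Cc1ccccn1)n1cnnc1` belongs to a small set of urea-type compounds built on a shared core and tested in a functional assay on MCF7 cells (Homo sapiens) for cytotoxicity, read by MTT assay, with a stated time of 48 h; a lower number here means a stronger inhibitor, a higher number a weaker inhibitor. In this assay compound 1 gives > 50000 nM, which is a limit of the test and not a number. Compound 2 `COc1ccc(CN(C(=O)Nc2ccc(Cl)c(C(F)(F)F)c2)n2cnnc2)cc1OC` stands at the same limit, giving > 50000 nM in this assay. Within the data shown here, compound 3 `Cc1ccsc1CN(C(=O)Nc1ccc(Cl)c(C(F)(F)F)c1)n1cnnc1` is the only member that returns a number, 30100 nM in this assay. Among the measured compounds shown here, the single counted step, an at least 1.6-fold lower number from compound 2 to compound 3 (0.22 log units; that floor lies within the scatter), is a change on a saturated chain carbon and is noted as lying within the scatter, so it shows no real movement. the limit of > 50000 nM in this assay, at which 2 of the 3 values shown sit, is where compound 1 and compound 2 both sit.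

Compound 4 `Cc1ccc(NC(=O)N(Cc2ccccn2)n2cnnc2)cc1` differs from compound 1 by 4-methylphenyl in place of benzyl on an amide-type nitrogen. For the measured compounds named here, no measured step touches this position, and the one step that exists concerns another part of the molecule and is itself within the scatter. Compound 2 and compound 3, which already carry an aryl group on that amide-type nitrogen, do not rise above weak activity, so the expected step of a number no higher from compound 1 to compound 4 (the limit leaves the size open) is none beyond the scatter. Compound 4 is therefore estimated at 50000 nM, within 15000 nM to 150000 nM, most likely reported again as a limit.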

Compound 4, half-maximal inhibitory concentration: 38900 nM
Beside the measured number, compound 4's estimate is 1.3-fold (0.11 log units) above it, and the stated range covers the measured number.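

Among these compounds, this is the first step at the amide-type nitrogen, and in this assay it reads as an at least 1.2-fold lower number from compound 1 to compound 4 (0.10 log units; that floor lies within the scatter). The exchange of benzyl for 4-methylphenyl leaves the heavy-atom count and the single six-membered aromatic ring of carbon only unchanged, and it takes the series from a limit to a measured number, yet the printed floor of the step stays inside the scatter, so it alone does not establish a real gain. The true size of the step stays unsettled because compound 1 stands at a limit and not at a number: the limit of > 50000 nM in this assay, at which 2 of the 4 values shown sit.

The compounds shown leave open whether a plain phenyl, a longer chain or a chain ending in an amine or a carboxylic acid on this amide-type nitrogen would move the number beyond the scatter. They also leave open whether 4-methylphenyl would give a comparable step with a group other than the one carried on the other side of the shared core of compound 1 and compound 4.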